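Amine end of the aryloxyethyl chain: compound 2 to compound 4

A few compounds are considered here, and "the series" means these few. Any claim that something is new, unique, unknown or untested is made for them only; others in the source may bear on it.

Compound 2 `CC(=O)/C(=C\c1ccccc1)Oc1ccccc1OCCCN(C(C)C)C(C)C` gives 0.1 mg/kg in a functional assay on the whole organism (heart) with Rattus norvegicus as the target (a higher number here means that more compound is needed for the effect, a lower number that less compound is needed), the lowest number of the three measured. Among the measured compounds shown here, compound 1 `CC(=O)/C(=C\c1ccccc1)Oc1ccccc1OCC(C)N(C)C` gives 0.9 mg/kg and compound 3 `CC(=O)/C(=C\c1ccccc1)Oc1ccc(OCC(O)NC(C)(C)C)cc1` gives 3.5 mg/kg; the step of a 9.0-fold lower number from compound 1 to compound 2 (0.95 log units; beyond the scatter) is the only measured step between compounds differing in one place, and it sets compound 2 beyond the scatter from compound 1, with compound 3 further still. Compound 4 `CC(=O)/C(=C\c1ccccc1)Oc1ccccc1OCC(O)CN1CCN(C)CC1` differs from compound 2 by 1-hydroxy-2-(4-methylpiperazin-1-yl)ethyl in place of 2-(diisopropylamino)ethyl on a saturated chain carbon bound to an oxygen on an aromatic ring. The step from compound 1 to compound 2 bears on this change, since it also alters only the amine end of the chain, and compound 4 moves away from the 2-(diisopropylamino)ethyl group that accompanied the lowest number. Compound 3, the other compound carrying a hydroxyl on the chain, shows the highest number, but it differs from compound 2 in more than one place, so only its value can be noted. A rise beyond the scatter is therefore expected, roughly reversing the measured step. Compound 4 is estimated at 1 mg/kg, within 0.3 mg/kg to 4 mg/kg, an expected step of a 10-fold higher number from compound 2 to compound 4 (1.00 log units; beyond the scatter).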

Compound 4, dose for half-maximal effect: 7.5 mg/kg
The estimate for compound 4 lay 7.5-fold (0.88 log units) below the measured number, and the stated range ends below it.
By their numbers in this assay, from the lowest: compound 2; then compound 1; then compound 3; then compound 4.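

In this assay, among the compounds shown here, the amine end of the chain spans a wider range than the earlier compounds showed: 1-hydroxy-2-(4-methylpiperazin-1-yl)ethyl in place of 2-(diisopropylamino)ethyl gives a 75-fold higher number from compound 2 to compound 4 (1.88 log units; beyond the scatter) on a saturated chain carbon bound to an oxygen on an aromatic ring. The same group in place of 1-(dimethylamino)ethyl gives an 8.3-fold higher number from compound 1 to compound 4 (0.92 log units; beyond the scatter) at this place, so compound 1 now stands beyond the scatter from both compound 2 and compound 4, with its number between theirs. No measurement is available that would explain the size of these steps.

The change to compound 4 brings in the hydroxyl and the piperazine ring together, and the compounds shown do not separate the two. Going by these compounds, it remains open how a diisopropylamino end on the hydroxyl-bearing chain, or a morpholine ring in place of the 4-methylpiperazine, would read.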